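Aryl group on the ring nitrogen: compound 3 to compound 4

The source may hold more compounds than are shown below. What is called first, only, known or untested is meant among the compounds shown, and "the series" means these compounds.

Measured compounds:
compound 1, `Cc1n[nH]c2ccc(-c3nc4cnc(N5CCN(C)CC5)cn4c3Nc3ccc(Cl)cc3)cc12`, gives 3510 nM in a functional assay on MV4-11 cells (Homo sapiens) for inhibition, with a stated time of 120 h; on this read-out higher numbers stand for weaker inhibition and lower numbers for stronger inhibition
compound 2, `Cc1cc(Br)ccc1Nc1c(-c2ccc3[nH]nc(C)c3c2)nc2cnc(N3CCN(C)CC3)cn12`, gives 10900 nM in this assay
compound 3, `Cc1n[nH]c2ccc(-c3nc4cnc(N5CCN(C)CC5)cn4c3Nc3ccc(F)cc3Br)cc12`, gives 3830 nM in this assay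

Compound 3 holds the second highest of the three numbers. Its gap to compound 1 is within the scatter, as a 1.1-fold higher number from compound 1 to compound 3 (0.04 log units; within the scatter) shows, while its gap to compound 2 lies beyond the scatter, as a 2.8-fold lower number from compound 2 to compound 3 (0.45 log units; beyond the scatter) shows.

Compound 4, `Cc1n[nH]c2ccc(-c3nc4cnc(N5CCN(C)CC5)cn4c3Nc3ccc(F)c(Cl)c3)cc12`, differs from compound 3 in one place: 3-chloro-4-fluorophenyl in place of 2-bromo-4-fluorophenyl on a nitrogen on an aromatic ring. The shared core and the substituted amine nitrogen are unchanged.

All three measured steps vary the same aryl group on this nitrogen and therefore bear on the change. Swapping 4-chlorophenyl for 2-bromo-4-fluorophenyl gave a 1.1-fold higher number from compound 1 to compound 3 (0.04 log units; within the scatter), a step within the scatter; swapping 4-chlorophenyl for 4-bromo-2-methylphenyl gave a 3.1-fold higher number from compound 1 to compound 2 (0.49 log units; beyond the scatter), a modest step; and a 2.8-fold lower number from compound 2 to compound 3 (0.45 log units; beyond the scatter) was the modest step back. Variation of the halogenated aryl group in this set has moved the numbers by at most modest amounts, and the change to compound 4 keeps a halogenated phenyl of the same size. The step from compound 3 to compound 4 is therefore expected to be a 1.1-fold lower number from compound 3 to compound 4 (0.04 log units; within the scatter), not beyond the scatter.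

Compound 4 is estimated at 3500 nM, within a range of 1200 nM to 10000 nM.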

Compound 4, half-maximal inhibitory concentration: 2850 nM
The estimate for compound 4 lay 1.2-fold (0.09 log units) above the measured number; low and high end bracket the measured number.
By their numbers in this assay, from the lowest: compounds 4, 1 and 3 (each within the scatter of the next); then compound 2.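

Working notes on the aryl group on the nitrogen: in this assay, 3-chloro-4-fluorophenyl stays level with the two earlier groups, with a 1.3-fold lower number from compound 3 to compound 4 (0.13 log units; within the scatter) and a 1.2-fold lower number from compound 1 to compound 4 (0.09 log units; within the scatter), so this position has now accepted three different halogen patterns without a shift beyond the scatter, even though the step to compound 4 changes both the halogen and its place on the ring. Compound 2 remains the one exception and the weakest of the set, as a 3.8-fold lower number from compound 2 to compound 4 (0.58 log units; beyond the scatter) confirms, so 4-bromo-2-methylphenyl now stands apart from all three of the other aryl groups rather than from two. No measurement bears on why compound 2 stands apart from the others.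

Since the step from compound 3 to compound 4 changes two features at once, the separate contributions of the chlorine and of its place on the ring stay unresolved. Going by these compounds, every group here is a substituted phenyl carrying a halogen, so it remains open how this position responds to an unsubstituted phenyl, a methoxy or nitrile substituent, a pyridine ring, or a phenyl bearing an amine or a carboxylic acid.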